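The source may report more compounds than this note shows. Statements on the series, on what has been measured and on what is new or still open speak of the compounds shown alone.

In a functional assay on HCT-116 cells (Homo sapiens) for cytotoxicity, read by sulforhodamine B assay, with a stated time of 24 h (on this read-out higher numbers stand for weaker inhibition and lower numbers for stronger inhibition), compound 1 (`Cc1ccc(/N=C2\C(=O)Nc3ccc(S(=O)(=O)N4CCOCC4)cc32)cc1`) gives 18900 nM, compound 2 (`Cc1ccc(S(=O)(=O)N/N=C2\C(=O)Nc3ccc(S(=O)(=O)N4CCOCC4)cc32)cc1`) gives 23400 nM and compound 3 (`O=C1Nc2ccc(S(=O)(=O)N3CCOCC3)cc2/C1=N/NC(=O)c1ccccc1`) gives 28900 nM. Compound 3 therefore stands level with the other two, with all three values within the scatter of one another. Compound 4 (`O=C1Nc2ccc(S(=O)(=O)N3CCOCC3)cc2/C1=N/Nc1ccccc1`) differs from compound 3 in one place: phenyl in place of benzoyl on an amine nitrogen. Among the compounds with values here, two measured steps bear on this change, a 1.5-fold higher number from compound 1 to compound 3 (0.18 log units; within the scatter) and a 1.2-fold higher number from compound 2 to compound 3 (0.09 log units; within the scatter). Both alter the same substituent, and neither exceeds the scatter, so no step beyond it is expected in this assay. The expected change is an estimated 1.2-fold lower number from compound 3 to compound 4 (0.08 log units; within the scatter). Compound 4 is estimated at 24000 nM, with an expected range from 12000 nM to 45000 nM.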

Compound 4, half-maximal inhibitory concentration: 10500 nM
Beside the measured number, compound 4's estimate is 2.3-fold (0.36 log units) above it, and the stated range ends above it.
By their numbers in this assay, from the lowest: compounds 4, 1, 2 and 3 (each within the scatter of the next, the first and the last beyond it).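

In this assay, within the data shown here, the group on this amine nitrogen now separates compounds, as phenyl in place of benzoyl gives a 2.8-fold lower number from compound 3 to compound 4 (0.44 log units; beyond the scatter) and phenyl in place of (4-methylphenyl)sulfonyl gives a 2.2-fold lower number from compound 2 to compound 4 (0.35 log units; beyond the scatter), both modest but beyond the scatter, unlike the earlier steps. By contrast, anilino in place of 4-methylphenyl on the double-bonded nitrogen gives a 1.8-fold lower number from compound 1 to compound 4 (0.26 log units; within the scatter) and stays within the scatter. Nothing available accounts for the size of these steps. The compounds shown leave open whether a methoxy or chloro group on the phenyl, or a methyl group in its place, would move the number further.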